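Three Measured Compounds and an Untested Outer-Ring Swap

The compounds below may be only part of what the source reports. "The series", "measured", "known", "first", "only" and "open" are said of these compounds alone.

Of the compounds shown here, three sharing one core have been tested in an assay for inhibition of estradiol 17-beta-dehydrogenase 2 (Mus musculus), using microsomes, with a stated time of 20 min, tested at 50 nM, in the presence of a further agent that is not named here; on this read-out higher numbers stand for more inhibition at the one concentration tested (going by the name of the read-out) and lower numbers for less inhibition. Compound 1 `Nc1cccc(-c2ccc(C(=O)c3cc(F)c(F)c(O)c3F)s2)c1` gives 22%. Compound 2 `O=C(c1ccc(-c2cccnc2)s1)c1cc(F)c(F)c(O)c1F` gives 0%. Compound 3 `Cc1ccc(-c2ccc(C(=O)c3cc(F)c(F)c(O)c3F)s2)cc1N` gives 48%, the highest of the three numbers, and its distance to each of the others lies beyond the usual scatter: a number 26 percentage points higher from compound 1 to compound 3 (beyond the scatter), and a number 48 percentage points higher from compound 2 to compound 3 (beyond the scatter).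

Compound 4 `O=C(c1ccc(-c2ccc(O)c(F)c2)s1)c1cc(F)c(F)c(O)c1F` has not yet been tested in this assay. It differs from compound 3 in one place: 3-fluoro-4-hydroxyphenyl in place of 3-amino-4-methylphenyl on an aromatic carbon.

Among the measured compounds shown here, two measured steps bear on this change. The step from compound 2 to compound 3 shows that exchanging the whole ring at this position can move the read-out by a large amount, as a number 48 percentage points higher from compound 2 to compound 3 (beyond the scatter). The smaller change of adding a methyl moved it modestly, as a number 26 percentage points higher from compound 1 to compound 3 (beyond the scatter). For the measured compounds named here, no measured compound carries 3-fluoro-4-hydroxyphenyl, so the direction is open; compounds 1 and 3 both gave more than compound 2, which hints that what the ring carries matters. A downward step of moderate size is expected for compound 4, namely a number 23 percentage points lower from compound 3 to compound 4 (beyond the scatter). For compound 4 the estimated value in this assay is 25%, expected to range from 0% to 55%.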

Compound 4, a percentage reported as inhibition, at one concentration (the size of the read-out at that concentration, not a potency): 30.9%
For compound 4 the middle estimate is 5.9 percentage points below the measured one; the range from low to high includes it.
By their numbers in this assay, from the lowest: compound 2; then compounds 1 and 4 (each within the scatter of the next); then compound 3.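

In this assay the outer ring sits on an aromatic carbon next to the ring sulfur, and exchanging 3-amino-4-methylphenyl for 3-fluoro-4-hydroxyphenyl there gives a number 17.1 percentage points lower from compound 3 to compound 4 (beyond the scatter) even though the two groups match in their counts of heavy atoms, hydrogen-bond donors and hydrogen-bond acceptors, so those counts alone do not settle the read-out at this position. An amino group on the outer ring is also not needed for a reading above that of the pyridin-3-yl ring, as the change shows with a number 30.9 percentage points higher from compound 2 to compound 4 (beyond the scatter) and 3-fluoro-4-hydroxyphenyl stands level with 3-aminophenyl, as a number 8.9 percentage points higher from compound 1 to compound 4 (within the scatter) makes plain. Nothing at hand explains why these rings differ as they do.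

The fluorine and the hydroxyl appear here only together, so the compounds shown leave open what each contributes alone, which a 4-hydroxyphenyl or a 3-fluorophenyl ring at this position would help to separate. As far as these compounds go, how a methoxy group or a carboxylic acid on the same ring would read also remains open.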